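The compounds below may be only part of what the source reports. "The series", "measured", "known", "first", "only" and "open" are said of these compounds alone.

Measured so far:
- compound 1 `Cc1cc(NC(=O)Cn2nnc(-c3ccccc3)n2)n(C2CC2)n1` — > 78%
- compound 2 `O=C(Cn1nnc(-c2ccccc2)n1)Nc1cc(C2CC2)nn1C1CCCCC1` — 45%
- compound 3 `Cc1cc(NC(=O)Cn2nnc(-c3cc(Cl)cc(Cl)c3)n2)n(C2CCCCC2)n1` — 82%

In an assay on HEK293 cells for activation of Kir3.1/Kir3.2 (Homo sapiens), read by thallium flux (on this read-out lower numbers stand for smaller maximal responses and higher numbers for larger maximal responses), compound 3 gives 82%, the higher of the two numbers in hand; compound 2, at 45%, sits beyond the scatter below it. For compound 1 the value > 78% is a limit of this assay rather than a number (the limit of > 78% in this assay, at which 1 of the 3 values shown sits). Compound 4 `Cc1cc(NC(=O)Cn2nnc(-c3cccc(C(F)(F)F)c3)n2)n(C2CCCCC2)n1` is not yet measured. It differs from compound 3 in one place: 3-(trifluoromethyl)phenyl in place of 3,5-dichlorophenyl on an aromatic carbon. For the measured compounds named here, no step between measured compounds bears on this exchange, so the size of the step in this assay cannot be read from the series. A modest downward step, or none beyond the scatter, is expected. Compound 4 is estimated at 70% (range 50% to 90%), meaning an expected a number 12 percentage points lower from compound 3 to compound 4 (beyond the scatter).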

Compound 4, largest response reached (Emax), in percent of the reference or control that the assay uses: 86%
Compound 4: middle estimate off by 16 percentage points, on the low side; the measured number falls inside the stated range.
By their numbers in this assay, from the lowest: compound 2; then compounds 3 and 4 (each within the scatter of the next).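

In this assay, for the compounds shown here, the exchange of 3,5-dichlorophenyl for 3-(trifluoromethyl)phenyl on the aromatic carbon gives a number 4 percentage points higher from compound 3 to compound 4 (within the scatter) and is the first step read at this position. In this one pair, the two chlorines of compound 3 are not needed to hold the maximal response. No available measurement explains this outcome.

Still open, from the compounds shown here alone, is whether this position tolerates a phenyl bearing an amine or a carboxylic acid. Also open, going by these compounds, is whether a non-aromatic group such as a longer alkyl chain can replace the aryl group.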